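Isoquinoline for phenyl on the longer-chain amide

The source may hold more compounds than are shown below. What is called first, only, known or untested is meant among the compounds shown, and "the series" means these compounds.

The measured compounds and their values:
compound 1, `CCCCCCCCCCCCNC(=O)[C@@H](NC(=O)c1ccccc1)[C@@H](C)O`, 200000 nM
compound 2, `CCCCCCCCCCCCNC(=O)[C@@H](NC(=O)c1nccc2ccccc12)[C@@H](C)O`, 65800 nM
compound 3, `CCCCCCCCCCCCCCCCCCNC(=O)[C@@H](NC(=O)c1ccccc1)[C@@H](C)O`, 200000 nM

In a functional assay on SW-620 cells (Homo sapiens) for cytotoxicity, read by MTT assay, with a stated time of 48 h (a higher number here means a weaker inhibitor, a lower number a stronger inhibitor), compound 3 gives 200000 nM. It stands level with compound 1, the two together the highest numbers of the three; its step to compound 2 is the largest, a 3.0-fold lower number from compound 1 to compound 2 (0.48 log units; beyond the scatter) tells how large that pairing runs, and no change at the digits printed from compound 1 to compound 3 (within the scatter) shows the longer chain alone moved nothing at the digits read.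

Compound 4, `CCCCCCCCCCCCCCCCCCNC(=O)[C@@H](NC(=O)c1nccc2ccccc12)[C@@H](C)O`, is the unmeasured member. It differs from compound 3 in one place: isoquinolin-1-yl in place of phenyl on a carbonyl carbon. The same exchange has been seen once, in the step from compound 1 to compound 2, where it gave a 3.0-fold lower number from compound 1 to compound 2 (0.48 log units; beyond the scatter). Because the chain extension left the number unchanged (no change at the digits printed from compound 1 to compound 3 (within the scatter)), the same modest drop is expected on the longer chain. Compound 4 is therefore estimated at 66000 nM in this assay, within 25000 nM to 200000 nM, a step of a 3.0-fold lower number from compound 3 to compound 4 (0.48 log units; beyond the scatter) expected from compound 3.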

Compound 4, half-maximal inhibitory concentration: 136000 nM
For compound 4 the middle estimate is 2.1-fold (0.31 log units) below the measured one, within the range that was stated.
By their numbers in this assay, from the lowest: compound 2; then compounds 4, 1 and 3 (each within the scatter of the next).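

In this assay, isoquinolin-1-yl in place of phenyl on the carbonyl carbon gives a 1.5-fold lower number from compound 3 to compound 4 (0.17 log units; within the scatter) on the longer chain, so the exchange that stood beyond the scatter on the shorter chain does not do so here. Even so, the two readings of this exchange cannot be told apart: the same change on two cores in this assay, a 3.0-fold lower number (0.48 log units; beyond the scatter) from compound 1 to compound 2 and a 1.5-fold lower number (0.17 log units; within the scatter) from compound 3 to compound 4, 2.1-fold (0.32 log units) apart, within the scatter of two such steps. Going by these compounds alone, the chain extension by hexyl, which gave no step with phenyl, gives a 2.1-fold higher number from compound 2 to compound 4 (0.32 log units; beyond the scatter) with isoquinolin-1-yl, yet that difference between the two readings also stays inside what such steps allow: the same change on two cores in this assay, no change at the digits printed (within the scatter) from compound 1 to compound 3 and a 2.1-fold higher number (0.32 log units; beyond the scatter) from compound 2 to compound 4, 2.1-fold (0.32 log units) apart, within the scatter of two such steps.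

The compounds shown leave open whether a pyridin-2-yl or a naphthalen-1-yl group on that carbonyl carbon would give a lower number than isoquinolin-1-yl. They also leave open what a shorter chain or a terminal carboxylic acid on the chain would do.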